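Swapping Two Methyls for Ethyls at a Chain End

A few compounds are considered here, and "the series" means these few. Any claim that something is new, unique, unknown or untested is made for them only; others in the source may bear on it.

Of the compounds shown here, two have so far been measured in a physicochemical assay for lipophilicity, using the shake flask method, measured as octanol-water partition, at pH 7.4; a lower number here means a more polar compound, a higher number a more lipophilic compound. Compound 1, `CCN(CC)CCCCOc1ccc(/C=C/C(=O)Nc2ccccc2)cc1OC`, gives 1.59. Compound 2, `COc1cc(/C=C/C(=O)Nc2ccccc2)ccc1OCCCCCCCCCCN(C)C`, gives 1.8, which is the higher of the two numbers, although the gap is too small to tell the two compounds apart with confidence. Compound 3, `CCN(CC)CCCCCCCCCCOc1ccc(/C=C/C(=O)Nc2ccccc2)cc1OC`, has not yet been measured. It differs from compound 2 in a single place: diethylamino in place of dimethylamino on a saturated chain carbon, ten or more bonds along the chain from an oxygen on an aromatic ring. Among the measured compounds shown here, only one measured step offers any guidance, and only in part: the step of a number 0.21 log units higher from compound 1 to compound 2 (within the scatter) bundled a longer chain with the reverse of this amine change, and it stayed within the scatter. That combined step being small, the amine change on its own is expected to be small as well, with an upward direction if any. Compound 3 is therefore expected to give 2.2 in this assay, with a likely range from 1.7 to 2.7. This corresponds to an expected step of a number 0.40 log units higher from compound 2 to compound 3 (beyond the scatter).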

Compound 3, partition coefficient: 1.83
Compound 3: the middle estimate sits 0.37 log units above what was measured, within the range that was stated.
By their numbers in this assay, from the lowest: compounds 1, 2 and 3 (each within the scatter of the next).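

In this assay, diethylamino in place of dimethylamino, on a saturated chain carbon, gives a number 0.03 log units higher from compound 2 to compound 3 (within the scatter) and so leaves no readable mark on this measurement at this place. The chain can now be read apart from the amine as well, since with diethylamino on both compounds the change to 6-(diethylamino)hexyl gives a number 0.24 log units higher from compound 1 to compound 3 (within the scatter) and, unlike the earlier step that bundled the chain with an amine change, this one alters the chain alone. Nothing available here accounts for how small these two steps are.

On these data alone, whether the swap from dimethylamino to diethylamino would read the same on a shorter chain, such as a butyl chain, remains open, as does the behaviour of chains of intermediate length. Also open, as far as these compounds go, is whether a ring amine such as piperidine, or a carboxylic acid in the amine's place, would stay equally close to these compounds in this assay.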